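The source may report more compounds than this note shows. Statements on the series, on what has been measured and on what is new or still open speak of the compounds shown alone.

Notes on the series. Compound 1 `CCCCCCCc1cc2cn([C@H]3C[C@H](O)[C@@H](CO)O3)c(=O)nc2o1` carries a saturated seven-carbon chain on the shared core and is tested in a functional assay on HEL cells (Homo sapiens) for cytotoxicity, read by microscopy; on this read-out lower numbers stand for higher toxicity in this test and higher numbers for lower toxicity in this test. In this assay compound 1 gives only a limit, > 50000 nM. Compound 2 `C=CCCCc1cc2cn([C@H]3C[C@H](O)[C@@H](CO)O3)c(=O)nc2o1` keeps the core and the sugar but bears a shorter unsaturated chain. In this assay compound 2 likewise gives only a limit, > 200000 nM. The step that the two limits leave unreadable from compound 1 to compound 2 is consequently not readable in size or direction. Compound 2 sits at the limit of > 200000 nM in this assay, at which 1 of the 2 values shown sits. Compound 1 sits at the limit of > 50000 nM in this assay, at which 1 of the 2 values shown sits. The two limits leave the comparison open.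

Compound 3 `C=CCCCCCCCCc1cc2cn([C@H]3C[C@H](O)[C@@H](CO)O3)c(=O)nc2o1` is not yet measured. It differs from compound 2 as follows: hept-6-en-1-yl in place of vinyl on a saturated chain carbon, three bonds along the chain from an aromatic carbon. Among the measured compounds shown here, the only measured step that bears on this change is a step that the two limits leave unreadable from compound 1 to compound 2, and its size cannot be read, so no step beyond the scatter is established in this assay for chain changes of this kind. Compound 3 is therefore expected to remain in the unresolved region of this assay, the step of an at least 2.0-fold lower number from compound 2 to compound 3 (0.30 log units; that floor lies within the scatter) being estimated as one that the limits would again hide. For compound 3 the estimate in this assay is 100000 nM, with a range from 20000 nM to 400000 nM.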

Compound 3, minimum cytotoxic concentration: > 50000 nM
Compound 3: no number, only a limit (the forecaster's own chance of this, stated with the estimate: 75%); the middle value lies beyond the limit too.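

In this assay compound 3 gives only a limit, > 50000 nM. Among the compounds shown here, compound 1, compound 2 and compound 3 all stand at limits, and no step among them can be read in size or direction. The compounds shown leave open whether any of these chains on the shared core gives a number rather than a limit in this assay.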